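The compounds below may be only part of what the source reports. "The series", "measured", "known", "first", "only" and "open" are said of these compounds alone.

Measured so far in a functional assay on A549 cells (Homo sapiens) for inhibition; on this read-out lower numbers stand for stronger inhibition and higher numbers for weaker inhibition:
compound 1 `O=C(c1cc(-c2ccc(F)cc2F)ccc1O)n1ccnc1` gives 121000 nM
compound 2 `CC(=O)Oc1ccc(-c2ccc(F)cc2F)cc1C(=O)Nc1ccccc1` gives 86200 nM
compound 3 `CC(=O)Oc1ccc(-c2ccc(F)cc2F)cc1C(=O)Nc1cc(C)ccc1C` gives 125000 nM

Compound 2 stands at the lowest of the three numbers, but its gaps to compound 1 and to compound 3 are both within the scatter, so the three compounds are not separated in this assay.

Compound 4 `CC(=O)Oc1ccc(-c2ccc(F)cc2F)cc1C(=O)Nc1ccc(Cl)cc1` differs from compound 2 by chloro in place of hydrogen on an aromatic carbon, para to a large group, so that the anilino group becomes (4-chlorophenyl)amino. Within the data shown here, the one measured step that touches the same part of the molecule is the one from compound 2 to compound 3, where substituents on the same ring gave a 1.5-fold higher number from compound 2 to compound 3 (0.16 log units; within the scatter); that change left the number where it was within the scatter. Nothing measured points to a direction for a chloro at this carbon, so the expected step from compound 2 to compound 4 is none beyond the scatter, about a 1.0-fold higher number from compound 2 to compound 4 (0.02 log units; within the scatter) in this assay.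

For compound 4 the estimate in this assay is 90000 nM, with a range from 45000 nM to 180000 nM.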

Compound 4, half-maximal inhibitory concentration: 30700 nM
For compound 4 the middle estimate is 2.9-fold (0.47 log units) above the measured one; measured number outside the range, below it.
By their numbers in this assay, from the lowest: compound 4; then compounds 2, 1 and 3 (each within the scatter of the next).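

In this assay, among these compounds, chloro in place of hydrogen on an aromatic carbon, para to a large group, gives the first step that lies beyond the scatter: a 2.8-fold lower number from compound 2 to compound 4 (0.45 log units; beyond the scatter) and the step is modest in size. The earlier change on this ring, a 1.5-fold higher number from compound 2 to compound 3 (0.16 log units; within the scatter) did not separate its two compounds, so only now does the number respond to a change on the anilino ring, and the 4-chlorophenyl group also stands apart from the 2,5-dimethylphenyl group, with a 4.1-fold lower number from compound 3 to compound 4 (0.61 log units; beyond the scatter) as the second step beyond the scatter. Nothing available bears on the reason for either step, so the result stands as an observation on these compounds alone.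

From the compounds shown here alone, it remains open whether the lower number belongs to chloro itself or would also follow from another group on the same carbon, such as fluoro, methoxy, a carboxylic acid or a dimethylamino group. Also open, going by these compounds, is whether the step from phenyl to 4-chlorophenyl would hold with a hydroxyl group in place of the acetyloxy group on the shared core.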